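Trimming a Trifluoromethyl from an Amide-Linked Pyrazole Series

A few compounds are considered here, and "the series" means these few. Any claim that something is new, unique, unknown or untested is made for them only; others in the source may bear on it.

Going by the values given here, compound 1 `COc1cc(-c2nn(-c3cccc(NC(=O)c4cccc(C(F)(F)F)c4)c3)cc2-c2ccncc2)ccc1Cl` is the only compound here with a number: in a functional assay on NCI/ADR-RES cells (Homo sapiens) for inhibition, read by sulforhodamine B assay, with a stated time of 48 h (a higher number here means a weaker inhibitor of growth, a lower number a stronger inhibitor of growth), compound 1 gives 3170 nM. Compound 2 `O=C(Nc1cccc(-n2cc(-c3ccncc3)c(-c3ccc(Cl)c(O)c3)n2)c1)Nc1ccc(Cl)c(Cl)c1` reaches only a limit of the assay, giving > 32500 nM in this assay. That value sits at the limit of > 32500 nM in this assay, at which 1 of the 2 values shown sits. Compound 3 `COc1cc(-c2nn(-c3cccc(NC(=O)c4ccccc4)c3)cc2-c2ccncc2)ccc1Cl` differs from compound 1 by hydrogen in place of trifluoromethyl on an aromatic carbon, meta to a large group. Among the compounds with values here, no measured pair here changes in a single place, so the size of this step has no direct guide. The step from compound 1 to compound 3 is expected to be a 2.1-fold higher number from compound 1 to compound 3 (0.31 log units; beyond the scatter), a modest weakening a little beyond the scatter. Compound 3 is expected to give 6500 nM, with a range from 2200 nM to 20000 nM.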

Compound 3, concentration for total growth inhibition: > 100000 nM
Compound 3 was reported as a limit; the forecaster's own chance of this, stated with the estimate: 15%; middle value at least 15-fold (1.18 log units) from the limit.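

In this assay, putting hydrogen in place of trifluoromethyl gives an at least 31-fold higher number from compound 1 to compound 3 (1.49 log units; beyond the scatter). Going by these compounds alone, this is the first change in a single place, and it shows that the measurable growth inhibition of compound 1 depends strongly on what sits at this position on the benzoyl ring. Compound 3 reaches only a limit, so the true size of this large step remains unknown: the limit of > 100000 nM in this assay, at which 1 of the 3 values shown sits.

Only trifluoromethyl and hydrogen can be compared at this position. Whether a methyl group, a chlorine atom or a methoxy group there would keep the growth inhibition of compound 1 stays open, as does the reason for the loss.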